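Methoxy addition on a second core: expected step for compound 4

The source may report more compounds than this note shows. Statements on the series, on what has been measured and on what is new or still open speak of the compounds shown alone.

Compound 1 `COc1cc(/C=C2\CCC/C(=C\c3cccc(OC)c3OC)C2=O)cc(OC)c1` and compound 2 `COc1cccc(/C=C2\CCC/C(=C\c3cc(OC)c(OC)c(OC)c3)C2=O)c1OC` share one core. In a functional assay on MCF7 cells (Homo sapiens) for cytotoxicity, read by MTT assay, with a stated time of 72 h (a lower number here means a stronger inhibitor, a higher number a weaker inhibitor), compound 1 gives 1700 nM, and compound 2 gives 1400 nM. The change between them is methoxy in place of hydrogen on an aromatic carbon, and it made a 1.2-fold lower number from compound 1 to compound 2 (0.08 log units; within the scatter). Compound 3 `COc1ccc(/C=C2\CCC/C(=C\c3ccc(OC)c(OC)c3)C2=O)cc1` gives 7800 nM in this assay, the highest number of the three; how its core differs from the core of compound 1 is not broken down here. Compound 4 `COc1ccc(/C=C2\CCC/C(=C\c3ccc(OC)c(OC)c3)C2=O)cc1OC` carries the same kind of change relative to compound 3: methoxy in place of hydrogen on an aromatic carbon. The surroundings differ: in compound 2 the entering methoxy sits ortho to two methoxy groups and para to a large group, in compound 4 ortho to a methoxy group and meta to a large group. The step is expected to be a 1.3-fold lower number from compound 3 to compound 4 (0.11 log units; within the scatter), resting on a 1.2-fold lower number from compound 1 to compound 2 (0.08 log units; within the scatter). Compound 4 is estimated at 6000 nM, between 2500 nM and 14000 nM.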

Compound 4, half-maximal inhibitory concentration: 13500 nM
For compound 4 the middle estimate is 2.3-fold (0.35 log units) below the measured one, and the stated range covers the measured number.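

In this assay methoxy in place of hydrogen on an aromatic carbon gives a 1.7-fold higher number from compound 3 to compound 4 (0.24 log units; within the scatter) and so stays within the scatter on this second core as well. Set beside the earlier step, the result on the two cores does not differ: the same change on two cores in this assay, a 1.2-fold lower number (0.08 log units; within the scatter) from compound 1 to compound 2 and a 1.7-fold higher number (0.24 log units; within the scatter) from compound 3 to compound 4, 2.1-fold (0.32 log units) apart, within the scatter of two such steps. This shows that the change carries across these two cores and these two surroundings without a readable step, but it fixes neither a direction nor a size for the step and says nothing about any other core.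

Every aromatic substituent shown is a methoxy group, so it stays open whether a hydroxy group, fluorine or an amine in the same place would give a step beyond the scatter. Also open, from the compounds shown here alone, is whether a longer alkoxy chain would do so.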